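This account rests on a few compounds, and the source may have more. Where it says the series, first, only, none or still open, it means among the compounds named here.

In an assay on isolated protein for inhibition of protein kinase C zeta type (Homo sapiens), with stated times of 1 h and 2.5 min, tested at 30 uM (a higher number here means more inhibition at the concentration tested (going by the name of the read-out), a lower number less inhibition), compound 1, `CCOC(=O)c1c(-c2ccc(OC)cc2)csc1N`, gives 100%. Compound 2, `CCOC(=O)c1c(-c2ccc(C(F)(F)F)cc2)csc1N`, gives 16%. The two differ by one change, (trifluoromethyl in place of methoxy on an aromatic carbon), and this change made a step of a number 84 percentage points lower from compound 1 to compound 2 (beyond the scatter).

Compound 3, `COc1cccc(-c2csc(N)c2C(=O)OCc2ccccc2)c1`, gives 57%. How its core differs from the core of compound 1 is not broken down here. Among the three measured compounds compound 3 stands second; against compound 2 it lies higher by a margin beyond the scatter, and against compound 1 it lies lower by a margin beyond the scatter.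

Compound 4, `Nc1scc(-c2cccc(C(F)(F)F)c2)c1C(=O)OCc1ccccc1`, is not yet measured. It arises from compound 3 by trifluoromethyl in place of methoxy on an aromatic carbon. Within the data shown here, this is the same kind of change as the one from compound 1 to compound 2, but not the same: in compound 2 the trifluoromethyl sits para to a large group, in compound 4 it sits meta to a large group. The change occurs twice among the compounds shown, and the only measured instance is the step from compound 1 to compound 2.

Because that step was a number 84 percentage points lower from compound 1 to compound 2 (beyond the scatter), a fall is expected here too. Compound 3 starts from a lower value than compound 1, so less room remains, and the step from compound 3 to compound 4 is estimated at a number 45 percentage points lower from compound 3 to compound 4 (beyond the scatter). Compound 4 is expected to give about 12%, with 0% to 35% as the likely span.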

Compound 4, a percentage reported as inhibition, at one concentration (the size of the read-out at that concentration, not a potency): 29%
Beside the measured number, compound 4's estimate is 17 percentage points below it; the range from low to high includes it.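

In this assay, the step is a number 28 percentage points lower from compound 3 to compound 4 (beyond the scatter), so trifluoromethyl in place of methoxy goes with a fall on this core as it did on the core of compound 1. Among these compounds, the direction of the change carries over between the two cores, but its size does not: the same change on two cores in this assay, a number 84 percentage points lower (beyond the scatter) from compound 1 to compound 2 and a number 28 percentage points lower (beyond the scatter) from compound 3 to compound 4, 56 percentage points apart, beyond the scatter of two such steps With only two pairs, this does not show a rule for the series, and it does not show what sets the size of the fall, since the two pairs differ both in their ester and in where the group sits on the aromatic ring, and these two differences cannot be separated here.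

The compounds shown leave open whether the fall would keep its size with the ethyl ester and the benzyl ester compared with the group held in one place on the ring, and whether the same holds for the group in the other place. They also leave open how other groups in that place, such as a chlorine, a hydroxyl or a dimethylamino group, would read on either core.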